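Swapping one amide side group in a level pair

This account rests on a few compounds, and the source may have more. Where it says the series, first, only, none or still open, it means among the compounds named here.

In a functional assay on KBVIN cells (Homo sapiens) for antiproliferative activity, read by sulforhodamine B assay, with a stated time of 3 days (a lower number here means a stronger inhibitor of growth, a higher number a weaker inhibitor of growth), compound 3 `CN1CCC(C(=O)Nc2cccc(Nc3ncc(F)c(Nc4ccc(F)cc4)n3)c2)CC1` gives 11900 nM. Compound 2 `O=C(Nc1cccc(Nc2ncc(F)c(Nc3ccc(F)cc3)n2)c1)c1cccc([N+](=O)[O-])c1` gives 11400 nM, within the scatter of compound 3. Compound 1 `COc1ccc(N2CCN(C)CC2)cc1Nc1ncc(F)c(Nc2ccc(F)cc2)n1` gives 910 nM, a lower number than compound 3 and beyond the scatter. Compound 4 `CN(C)CC(=O)Nc1cccc(Nc2ncc(F)c(Nc3ccc(F)cc3)n2)c1` changes one group of compound 3: (dimethylamino)methyl in place of 1-methylpiperidin-4-yl on a carbonyl carbon. The change sits on a carbonyl carbon, where (dimethylamino)methyl replaces 1-methylpiperidin-4-yl. Among the compounds with values here, only one measured step changes a group at that place: a 1.0-fold higher number from compound 2 to compound 3 (0.02 log units; within the scatter). That step stayed within the scatter, so no shift beyond the scatter is expected in this assay. The expected size is small: a 1.2-fold lower number from compound 3 to compound 4 (0.08 log units; within the scatter). Compound 4 is estimated at 10000 nM, with an expected range of 4500 nM to 20000 nM.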

Compound 4, concentration for 50% growth inhibition: 1810 nM
Beside the measured number, compound 4's estimate is 5.5-fold (0.74 log units) above it, outside the stated range (below it).
By their numbers in this assay, from the lowest: compounds 1 and 4 (each within the scatter of the next); then compounds 2 and 3 (each within the scatter of the next).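

In this assay the group on this carbonyl carbon can move the number after all: the level pair gave no sign of this, yet (dimethylamino)methyl in place of 1-methylpiperidin-4-yl brings a 6.6-fold lower number from compound 3 to compound 4 (0.82 log units; beyond the scatter), and in place of 3-nitrophenyl it brings a 6.3-fold lower number from compound 2 to compound 4 (0.80 log units; beyond the scatter). The two groups with a ring sit level, while the one without a ring stands apart, though three groups are too few to make this a pattern. Nothing shown explains the shift. As far as these compounds go, whether a longer chain ending in the same amine would hold this gain remains open, as does the effect of a carboxylic acid here.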